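From piperazin-1-yl to methyl on the shared core

The compounds below may be only part of what the source reports. "The series", "measured", "known", "first", "only" and "open" are said of these compounds alone.

Among the measured compounds shown here, in a functional assay on MDA-MB-231 cells (Homo sapiens) for inhibition, read by MTT assay, with a stated time of 72 h (a lower number here means a stronger inhibitor, a higher number a weaker inhibitor), compound 3 `CC(C)(C)n1cc2c(n1)C(=O)CC1(CCN(C(=O)c3cc(N4CCNCC4)nc4ccccc34)CC1)O2` gives 4200 nM, the only true number in the set. Compound 1 `CC(C)(C)n1cc2c(n1)C(=O)CC1(CCN(C(=O)c3cc(-c4ccccc4)nc4ccccc34)CC1)O2` gives > 10000 nM, which is a limit of the assay. Compound 2 `CC(C)(C)n1cc2c(n1)C(=O)CC1(CCN(C(=O)c3cc(-c4ccc(Cl)cc4)nc4ccccc34)CC1)O2` gives > 10000 nM, again a limit. Between these two limits lies a step that the two limits leave unreadable from compound 1 to compound 2.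

Compound 4 `Cc1cc(C(=O)N2CCC3(CC2)CC(=O)c2nn(C(C)(C)C)cc2O3)c2ccccc2n1` carries methyl in place of piperazin-1-yl on an aromatic carbon.

For the measured compounds named here, two measured steps bear on this site. Piperazin-1-yl in place of phenyl gives an at least 2.3-fold lower number from compound 1 to compound 3 (0.37 log units; beyond the scatter), and piperazin-1-yl in place of 4-chlorophenyl gives an at least 2.3-fold lower number from compound 2 to compound 3 (0.37 log units; beyond the scatter). Both end at compound 3, and neither tests methyl directly. Removing piperazin-1-yl is therefore expected to weaken inhibition, with the number moving up towards the limit. The expected change is a 2.4-fold higher number from compound 3 to compound 4 (0.38 log units; beyond the scatter) in this assay. A report of the limit alone is also more likely than not. For compound 4 the estimated value is 10000 nM, with an expected range from 4500 nM to 25000 nM.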

Compound 4, half-maximal inhibitory concentration: 4860 nM
For compound 4 the middle estimate is 2.1-fold (0.31 log units) above the measured one, and the stated range covers the measured number.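

In this assay, methyl serves this position as well as piperazin-1-yl does, with a 1.2-fold higher number from compound 3 to compound 4 (0.06 log units; within the scatter), so that ring and its hydrogen-bond donor are not required for a readable number on the shared core. The earlier steps could have credited piperazin-1-yl itself, yet methyl in place of phenyl gives an at least 2.0-fold lower number from compound 1 to compound 4 (0.31 log units; beyond the scatter) and methyl in place of 4-chlorophenyl gives an at least 2.0-fold lower number from compound 2 to compound 4 (0.31 log units; beyond the scatter), which leaves the compounds with phenyl or 4-chlorophenyl as the weaker pair among these four. Both of these steps start from a limit and are bounded on one side only: the limit of > 10000 nM in this assay, at which 2 of the 4 values shown sit.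

As far as these compounds go, whether the weaker result belongs to an aromatic ring at this position or to any larger ring stays open, and cyclohexyl would separate the two. Also open, from the compounds shown here alone, is whether any group here, such as a short open-chain amine or a carboxylic acid, brings the number clearly below those of compound 3 and compound 4.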